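A few compounds are considered here, and "the series" means these few. Any claim that something is new, unique, unknown or untested is made for them only; others in the source may bear on it.

Measured so far:
compound 1 `Cc1cc(C)nc(SCc2cc(=O)c3cc(Cl)ccc3o2)n1`: > 25000 nM
compound 2 `Cc1nnc(Sc2coc3ccccc3c2=O)s1`: > 50000 nM

In a functional assay on MDA-MB-435S cells (Homo sapiens) for cytotoxicity, read by MTT assay, with a stated time of 72 h (a higher number here means a weaker inhibitor, a lower number a stronger inhibitor), compound 1 gives > 25000 nM, which is a limit of the assay and not a number; this is the limit of > 25000 nM in this assay, at which 1 of the 2 values shown sits. Compound 2 gives > 50000 nM, again a limit, (the limit of > 50000 nM in this assay, at which 1 of the 2 values shown sits). Both values shown are limits, so compound 1 stands at the limit and cannot be placed against compound 2 at all; neither compound shows measurable cytotoxicity here.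

Compound 3 `Cc1ccc2oc(CSc3nc(C)cc(C)n3)cc(=O)c2c1` differs from compound 1 by methyl in place of chloro on an aromatic carbon. For the measured compounds named here, no measured step for this change exists, so nothing beyond the scatter is expected in this assay in either direction; the likely outcome is another limit. The expected step is a step that the limit leaves unreadable from compound 1 to compound 3. Compound 3 is therefore estimated at 40000 nM, with a range from 15000 nM to 120000 nM.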

Compound 3, half-maximal inhibitory concentration: > 25000 nM
Compound 3: only a limit was reported; the forecaster's own chance of this, stated with the estimate: 85%; the middle value does not contradict the limit.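

No step can be read from compound 1 to compound 3, since both stand at the same limit of the assay: the limit of > 25000 nM in this assay, at which 2 of the 3 values shown sit. None of compounds 1, 2 and 3 gives a number in this assay, which leaves open whether methyl in place of chloro changes cytotoxicity at all.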